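Aryl hydrazone swaps on the shared core

A few compounds are considered here, and "the series" means these few. Any claim that something is new, unique, unknown or untested is made for them only; others in the source may bear on it.

Measured so far:
compound 1 `CN(C)CCn1cnnc1-c1cc(Oc2ccc(NC(=O)N/N=C/c3ccc(F)cc3)cc2F)ccn1`: 1370 nM
compound 2 `COc1cc(/C=N/NC(=O)Nc2ccc(Oc3ccnc(-c4nncn4CCN(C)C)c3)c(F)c2)cc(OC)c1OC`: 3620 nM

In a functional assay on HT-29 cells (Homo sapiens) for cytotoxicity, read by MTT assay, with a stated time of 72 h (on this read-out lower numbers stand for stronger inhibition and higher numbers for weaker inhibition), compound 1 gives 1370 nM, and compound 2 gives 3620 nM. Compound 2 thus stands highest of the two numbers; its nearest neighbour is compound 1, and the step between them was a 2.6-fold higher number from compound 1 to compound 2 (0.42 log units; beyond the scatter).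

Compound 3 `CN(C)CCn1cnnc1-c1cc(Oc2ccc(NC(=O)N/N=C/c3ccc(Cl)cc3)cc2F)ccn1` is not yet measured. It differs from compound 2 by 4-chlorophenyl in place of 3,4,5-trimethoxyphenyl on a carbon with a double bond to nitrogen. Among the compounds with values here, the only measured step that bears on this change is a 2.6-fold higher number from compound 1 to compound 2 (0.42 log units; beyond the scatter), which exchanged a 4-fluorophenyl for the 3,4,5-trimethoxyphenyl at the same carbon. Compound 3 carries a 4-chlorophenyl at that carbon, which is closer in kind to the 4-fluorophenyl of compound 1 than to the 3,4,5-trimethoxyphenyl of compound 2. Compound 3 is therefore expected to land near compound 1, with a step of a 2.8-fold lower number from compound 2 to compound 3 (0.44 log units; beyond the scatter) roughly undoing the earlier increase. For compound 3 the estimate is 1300 nM, within a range of 500 nM to 3600 nM.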

Compound 3, half-maximal inhibitory concentration: 530 nM
For compound 3 the middle estimate is 2.5-fold (0.39 log units) above the measured one, and the stated range covers the measured number.
By their numbers in this assay, from the lowest: compound 3; then compound 1; then compound 2.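

Within this assay, the exchange of 3,4,5-trimethoxyphenyl for 4-chlorophenyl on the carbon with a double bond to nitrogen gives a 6.8-fold lower number from compound 2 to compound 3 (0.83 log units; beyond the scatter), so the aryl group of the hydrazone can move the number in the favourable direction as well as the unfavourable one. The new information is that this position also responds to a single-atom exchange: chloro in place of fluoro on an aromatic carbon gives a 2.6-fold lower number from compound 1 to compound 3 (0.41 log units; beyond the scatter), which places the two halogen-bearing compounds apart, beyond the usual scatter, rather than together as one class of aryl group.

As far as these compounds go, three aryl groups cannot separate the effect of the halogen from that of ring substitution in general, so it remains open whether an unsubstituted phenyl, a 4-bromophenyl or a 4-trifluoromethylphenyl would continue the change from fluoro to chloro or break it. From the compounds shown here alone, it is also open whether the high number of compound 2 goes with methoxy groups as such or with their number, a question that a single 4-methoxyphenyl on the shared core would address. Nothing available explains either step.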